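This account rests on a few compounds, and the source may have more. Where it says the series, first, only, none or still open, it means among the compounds named here.

Working notes on the series. Compound 1 `NC(=O)c1c(NC(=O)c2ccccc2Cl)sc2c1CCN(Cc1ccc([N+](=O)[O-])cc1)C2` and compound 2 `NC(=O)c1c(NC(=O)c2ccccc2Cl)sc2c1CCN(C(=O)Nc1ccccc1Cl)C2` share the same core and differ only on the amine nitrogen in the ring; in a functional assay on HeLa cells (Homo sapiens) for antiproliferative activity, with a stated time of 24 h (a higher number here means a weaker inhibitor, a lower number a stronger inhibitor), compound 1 gives 46100 nM and compound 2 gives 45400 nM. For the measured compounds named here, the step of a 1.0-fold lower number from compound 1 to compound 2 (0.01 log units; within the scatter) is within the scatter, so compound 2 is not separated from compound 1 on the numbers so far: both weak inhibitors at the same level.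

Compound 3 `COc1ccc(NC(=S)N2CCc3c(sc(NC(=O)c4ccccc4Cl)c3C(N)=O)C2)cc1` is the next member. Relative to compound 2 the change is a group of 11 heavy atoms (8 carbon, 1 nitrogen, 1 oxygen, 1 sulfur; one six-membered aromatic ring of carbon only) in place of a group of 10 heavy atoms (7 carbon, 1 nitrogen, 1 oxygen, 1 chlorine; one six-membered aromatic ring of carbon only), on an amine nitrogen in a ring. Going by the values given here, the one measured step bearing on it, a 1.0-fold lower number from compound 1 to compound 2 (0.01 log units; within the scatter), exchanged the whole group on that nitrogen without moving the number beyond the scatter; no other step exists. The expectation is therefore no step beyond the scatter, the estimated move being a 1.0-fold lower number from compound 2 to compound 3 (0.00 log units; within the scatter). Compound 3 is expected to give about 45000 nM, within a range of 20000 nM to 100000 nM.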

Compound 3, half-maximal inhibitory concentration: 36400 nM
For compound 3 the middle estimate is 1.2-fold (0.09 log units) above the measured one, and the stated range covers the measured number.
By their numbers in this assay, from the lowest: compounds 3, 2 and 1 (each within the scatter of the next).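

In this assay, the step of a 1.2-fold lower number from compound 2 to compound 3 (0.10 log units; within the scatter) and the step of a 1.3-fold lower number from compound 1 to compound 3 (0.10 log units; within the scatter) are both within the scatter. The group with sulfur and oxygen that takes the place of (2-chlorophenyl)carbamoyl on the amine nitrogen in a ring therefore does not separate compound 3 from compound 2 or compound 1, so three different groups at this position now sit at one level. No supporting data are available to explain this result.

As far as these compounds go, whether a carboxylic acid, an amine or a longer alkyl chain on this nitrogen would give a number beyond the scatter of these three remains open. From the compounds shown here alone, the shared core is the same in all three compounds, so the contribution of its other groups also remains open.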